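Aryl change from compound 3 to compound 4

A few compounds are considered here, and "the series" means these few. Any claim that something is new, unique, unknown or untested is made for them only; others in the source may bear on it.

Of the compounds shown here, three on a shared core have been measured in an ADME assay on HEK293 cells (Homo sapiens) for cytotoxicity, read by MTT assay, with a stated time of 24 h; a lower number here means a stronger inhibitor, a higher number a weaker inhibitor: compound 1 `Cc1ccc(CNc2nc3ccc([N+](=O)[O-])cc3nc2NCCCN(C)C)cc1` gives 15.8 ug/mL, compound 2 `COc1ccc(CNc2nc3ccc([N+](=O)[O-])cc3nc2NCCCN(C)C)cc1` gives 38.6 ug/mL, and compound 3 `Cc1ccccc1CNc1nc2ccc([N+](=O)[O-])cc2nc1NCCCN(C)C` gives 27.6 ug/mL. Compound 3 cannot be separated from either of the others on these numbers. The steps that reach it are a 1.7-fold higher number from compound 1 to compound 3 (0.24 log units; within the scatter) and a 1.4-fold lower number from compound 2 to compound 3 (0.15 log units; within the scatter), and both lie within the scatter.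

Compound 4 `CN(C)CCCNc1nc2cc([N+](=O)[O-])ccc2nc1NCc1cccc(Br)c1` has 3-bromophenyl in place of 2-methylphenyl on a saturated chain carbon bound to a nitrogen on an aromatic ring. Among the compounds with values here, no measured compound carries bromine, so the evidence for this change is indirect. The two steps above are the closest precedents, since each replaces one substituted phenyl with another at this same place. Within the data shown here, the only step beyond the scatter is a 2.4-fold higher number from compound 1 to compound 2 (0.39 log units; beyond the scatter), which is modest and comes from methoxy in place of methyl on an aromatic carbon. On this evidence, no step beyond the scatter is expected in this assay, and no direction is firmly indicated. The estimated step is a 1.3-fold lower number from compound 3 to compound 4 (0.10 log units; within the scatter). For compound 4 the estimated value is 22 ug/mL, with an expected range of 10 ug/mL to 48 ug/mL.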

Compound 4, half-maximal inhibitory concentration: 3.66 ug/mL
Compound 4: middle estimate off by 6.0-fold (0.78 log units), on the high side; the measured number lies below the stated range.
By their numbers in this assay, from the lowest: compound 4; then compounds 1, 3 and 2 (each within the scatter of the next, the first and the last beyond it).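

With 3-bromophenyl on the saturated chain carbon bound to a nitrogen on an aromatic ring, this assay shows that this place can move the number well beyond the scatter: the change gives a 7.5-fold lower number from compound 3 to compound 4 (0.88 log units; beyond the scatter) and so exceeds the earlier swaps among substituted phenyl groups, of which a 1.7-fold higher number from compound 1 to compound 3 (0.24 log units; within the scatter) and a 1.4-fold lower number from compound 2 to compound 3 (0.15 log units; within the scatter) stayed within the scatter. The 3-bromophenyl group also stands apart from the other two phenyl groups, with a 4.3-fold lower number from compound 1 to compound 4 (0.64 log units; beyond the scatter) and an 11-fold lower number from compound 2 to compound 4 (1.02 log units; beyond the scatter), which leaves compound 4 with the lowest number of the series and a gap beyond the scatter to each of the others. Nothing shown here accounts for this shift.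

Within the data shown here, compound 4 is the only compound carrying bromine and the only one substituted at this ring place, so the contributions of the halogen and of its place on the phenyl ring cannot be separated. From the compounds shown here alone, it also remains open whether chlorine, fluorine or trifluoromethyl on the phenyl ring, or a pyridine ring in place of the phenyl ring, would give a similar number.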